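Fluoro in place of chloro on compound 2

A few compounds are considered here, and "the series" means these few. Any claim that something is new, unique, unknown or untested is made for them only; others in the source may bear on it.

Compound 1 `Cc1c(Cc2c(F)cccc2F)nc(SCc2ccncc2)[nH]c1=O`: > 70000 nM
Compound 2 `Cc1c(Cc2c(F)cccc2Cl)nc(SCC(=O)c2ccc(F)cc2)[nH]c1=O`: > 59000 nM

In an ADME assay on MT4 cells (Homo sapiens) for cytotoxicity, read by MTT assay (on this read-out lower numbers stand for higher toxicity in this test and higher numbers for lower toxicity in this test), compound 2 gives > 59000 nM, which is a limit and not a number. Compound 3 `Cc1c(Cc2c(F)cccc2F)nc(SCC(=O)c2ccc(F)cc2)[nH]c1=O` has fluoro in place of chloro on an aromatic carbon, turning 2-chloro-6-fluorobenzyl into 2,6-difluorobenzyl. Compound 1 carries that 2,6-difluorobenzyl group and also gives only a limit, > 70000 nM. No change beyond the scatter is therefore expected in this assay. The estimated step is a step that the limit leaves unreadable from compound 2 to compound 3. Compound 3 is expected at 65000 nM, within an estimated range of 30000 nM to 110000 nM.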

Compound 3, half-maximal cytotoxic concentration: > 62000 nM
Compound 3 ended at the assay's limit; the forecaster's own chance of this, stated with the estimate: 85%; the middle value is on the limit's open side.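

In this assay, no step can be read from compound 2 to compound 3 or from compound 1 to compound 3, as all three values are limits. The compounds shown leave open whether fluoro in place of chloro changes cytotoxicity at all.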